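Reducing the Ketone: Compound 3 to Compound 4

The source may report more compounds than this note shows. Statements on the series, on what has been measured and on what is new or still open speak of the compounds shown alone.

Measured compounds:
Compound 1, `COc1cccc(S(=O)(=O)c2ccccc2Cc2c3c(n(CC(=O)O)c2C)CCNC3=O)c1`, gives 12 nM.
Compound 2, `Cc1c(Cc2ccccc2Cn2ccnn2)c2c(n1CC(=O)O)CCNC2=O`, gives 800 nM.
Compound 3, `Cc1c(Cc2ccccc2C(=O)c2ccccc2)c2c(n1CC(=O)O)CCNC2=O`, gives 810 nM.

Compound 3 holds the highest number of the three in a functional assay on CHO.K1 cells for antagonist activity at prostaglandin D2 receptor 2 (Homo sapiens), read by GTPgammaS binding, with a stated time of 1 h; on this read-out higher numbers stand for weaker inhibition and lower numbers for stronger inhibition. Its nearest neighbour is compound 2, and the two lie within the scatter of each other, as the step of a 1.0-fold higher number from compound 2 to compound 3 (0.01 log units; within the scatter) shows; the step of a 68-fold higher number from compound 1 to compound 3 (1.83 log units; beyond the scatter) sets it far from compound 1.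

Compound 4, `Cc1c(Cc2ccccc2C(O)c2ccccc2)c2c(n1CC(=O)O)CCNC2=O`, has not yet been measured. It differs from compound 3 in one place: hydroxy(phenyl)methyl in place of benzoyl on an aromatic carbon. Going by the values given here, none of the measured steps changes a benzoyl into a hydroxy(phenyl)methyl, so no step bears directly on this change. The steps that do exist, a 67-fold higher number from compound 1 to compound 2 (1.82 log units; beyond the scatter) and a 68-fold higher number from compound 1 to compound 3 (1.83 log units; beyond the scatter), were large, while a 1.0-fold higher number from compound 2 to compound 3 (0.01 log units; within the scatter) fell within the scatter; together they show that the group on this aromatic carbon can matter greatly, but give no direction for the present change. The writer therefore expects for compound 4 a step of a 1.0-fold lower number from compound 3 to compound 4 (0.01 log units; within the scatter), that is, none beyond the scatter. The estimate for compound 4 in this assay is 800 nM, within a range from 250 nM to 2600 nM.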

Compound 4, half-maximal inhibitory concentration: 32 nM
For compound 4 the middle estimate is 25-fold (1.40 log units) above the measured one, and the stated range ends above it.
By their numbers in this assay, from the lowest: compound 1; then compound 4; then compounds 2 and 3 (each within the scatter of the next).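

In this assay, hydroxy(phenyl)methyl in place of benzoyl on this aromatic carbon, ortho to a large group, gives a 25-fold lower number from compound 3 to compound 4 (1.40 log units; beyond the scatter), so a change that keeps the heavy-atom count, gains a hydrogen-bond donor and loses a double bond outside aromatic rings can matter greatly here. The same group also separates from the (1H-1,2,3-triazol-1-yl)methyl group, with a 25-fold lower number from compound 2 to compound 4 (1.40 log units; beyond the scatter), although benzoyl and that group had stood within the scatter of each other. Against the (3-methoxyphenyl)sulfonyl group, it leaves only a modest gap, with a 2.7-fold higher number from compound 1 to compound 4 (0.43 log units; beyond the scatter).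

The compounds shown offer no evidence on what lies behind the gain. On these data alone, whether an amine or a methoxy group in place of the hydroxy on that carbon would keep the gain remains open.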